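Two methoxy groups instead of one on the anilino ring

This account rests on a few compounds, and the source may have more. Where it says the series, first, only, none or still open, it means among the compounds named here.

Compound 2 `COc1ccc(Nc2nc(SCc3ccc(C(F)(F)F)cc3)nc3ccccc23)cc1` carries a (4-methoxyphenyl)amino group on its core. Going by the values given here, in a functional assay on HGC-27 cells (Homo sapiens) for cytotoxicity, read by MTT assay, with a stated time of 72 h (on this read-out lower numbers stand for stronger inhibition and higher numbers for weaker inhibition), compound 2 gives 23500 nM, the only plain number among the values shown. Compound 1 `FC(F)(F)c1ccc(CSc2nc(N3CCCCC3)c3ccccc3n2)cc1` bears piperidin-1-yl at that aromatic carbon instead. In this assay compound 1 reaches only a limit of the assay, > 50000 nM, not a number. Among the compounds with values here, the single measured step, an at least 2.1-fold lower number from compound 1 to compound 2 (0.32 log units; beyond the scatter), rests on the limit of > 50000 nM in this assay, at which 1 of the 2 values shown sits, and concerns the group on the core, not the pattern of the phenyl ring. Compound 3 `COc1cc(Nc2nc(SCc3ccc(C(F)(F)F)cc3)nc3ccccc23)cc(OC)c1` differs from compound 2 by 3,5-dimethoxyphenyl in place of 4-methoxyphenyl on a nitrogen on an aromatic ring. Within the data shown here, no measured step covers this kind of change, and a step within the usual scatter is expected in this assay. Compound 3 is estimated at 22000 nM, with a range from 8000 nM to 60000 nM. The expected step of a 1.1-fold lower number from compound 2 to compound 3 (0.03 log units; within the scatter) is thus small and uncertain in direction.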

Compound 3, half-maximal inhibitory concentration: > 50000 nM
Compound 3: a limit, no number (the forecaster's own chance of this, stated with the estimate: 25%); middle value at least 2.2-fold (0.35 log units) from the limit.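

Replacing 4-methoxyphenyl with 3,5-dimethoxyphenyl on this nitrogen gives an at least 2.1-fold higher number from compound 2 to compound 3 (0.32 log units; beyond the scatter) in this assay, so the higher number means weaker inhibition. The earlier step exchanged the whole group on the core, whereas this one shows that the methoxy pattern on the phenyl ring alone can change the read-out. Compound 3 gives only a limit of the assay, not a number, so compound 2 remains the only compound with a plain value, and the steps between compound 1 and compound 3 cannot be read: the limit of > 50000 nM in this assay, at which 2 of the 3 values shown sit.

The compounds shown leave open whether the change follows the added methoxy group or the loss of the 4-methoxy pattern, which 3-methoxyphenyl or 3,4-dimethoxyphenyl could separate. From the compounds shown here alone, how a 4-hydroxyphenyl or 4-aminophenyl group would read on this nitrogen also remains open.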